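The compounds below may be only part of what the source reports. "The series", "measured", "known", "first", "only" and "open" are said of these compounds alone.

Compound 1 `COCCNc1nc(F)c(-c2nn(Cc3ccc(C#N)cc3)c(=O)c3ccccc23)cc1Cl` was examined in an ADME assay on HepG2 2.2.15 cells (Homo sapiens) for cytotoxicity, read by MTT assay, with a stated time of 8 days; on this read-out lower numbers stand for higher toxicity in this test and higher numbers for lower toxicity in this test. In this assay compound 1 reaches only a limit of the assay, > 100000 nM, so no number stands for it. Compound 1 thus sits at the limit of > 100000 nM in this assay, at which 1 of the 2 values shown sits. Compound 2 `Cc1cc(-c2ccc(F)nc2F)nn(Cc2ccc(Cl)cc2)c1=O` gives 83800 nM in this assay. Compound 3 `N#Cc1ccc(Cn2nc(-c3cc(Cl)c(NC[C@H](O)CO)nc3F)c3ccccc3c2=O)cc1` differs from compound 1 by 1,2-dihydroxyethyl in place of methoxymethyl on a saturated chain carbon bound to a nitrogen on an aromatic ring. Among the measured compounds shown here, no measured pair shows this change, and the step from compound 1 to compound 3 is expected to stay within the scatter, at a step that the limit leaves unreadable from compound 1 to compound 3. Compound 3 is therefore estimated at 120000 nM in this assay, with a range from 50000 nM to 300000 nM, most likely again reported only as a limit.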

Compound 3, half-maximal cytotoxic concentration: > 100000 nM
Compound 3 was reported as a limit; the forecaster's own chance of this, stated with the estimate: 70%; the middle value lies beyond the limit too.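

Compound 1 and compound 3 both stand only at a limit in this assay, so no step can be read between them: the limit of > 100000 nM in this assay, at which 2 of the 3 values shown sit.

The compounds shown leave open whether 1,2-dihydroxyethyl in place of methoxymethyl changes the half-maximal cytotoxic concentration at all.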